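A few compounds are considered here, and "the series" means these few. Any claim that something is new, unique, unknown or untested is made for them only; others in the source may bear on it.

Measured in a functional assay on DU-145 cells (Homo sapiens) for cytotoxicity, read by sulforhodamine B assay, with a stated time of 48 h; a higher number here means a weaker inhibitor, a lower number a stronger inhibitor:
compound 1 `CC(=O)OC[C@H]1O[C@@H](n2cc(CN3C(=O)/C(=C\c4ccccc4)c4ccccc43)nn2)[C@H](OC(C)=O)[C@@H](OC(C)=O)[C@@H]1OC(C)=O` gives 24100 nM;
compound 2 `CC(=O)OC[C@H]1O[C@@H](n2cc(CN3C(=O)/C(=C\c4ccc(N(C)C)cc4)c4ccccc43)nn2)[C@H](OC(C)=O)[C@@H](OC(C)=O)[C@@H]1OC(C)=O` gives 10100 nM;
compound 3 `CC(=O)OC[C@H]1O[C@@H](n2cc(CN3C(=O)/C(=C/c4cccs4)c4ccccc43)nn2)[C@H](OC(C)=O)[C@@H](OC(C)=O)[C@@H]1OC(C)=O` gives 23400 nM.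

In this assay compound 3 and compound 1 give numbers that lie within the usual scatter of each other, while compound 2 gives a lower number that lies beyond it. For the measured compounds named here, the only measured step between close relatives is a 2.4-fold lower number from compound 1 to compound 2 (0.38 log units; beyond the scatter), a swap of a group on an aromatic carbon.

Compound 4 `CC(=O)OC[C@H]1O[C@@H](n2cc(CN3C(=O)/C(=C\c4cccs4)c4ccccc43)nn2)[C@H](OC(C)=O)[C@@H](OC(C)=O)[C@@H]1OC(C)=O` differs from compound 3 only in that (the two compounds have the same atoms and bonds and differ only in configuration as drawn: 1 of 6 stereo elements differ; a double bond is drawn E in compound 3 and Z in compound 4). Going by the values given here, no measured step concerns a change of double-bond geometry, so the data give no basis for expecting a shift beyond the scatter in either direction. Compound 4 is therefore estimated at 23000 nM, with a range from 8000 nM to 65000 nM, which means an expected step of a 1.0-fold lower number from compound 3 to compound 4 (0.01 log units; within the scatter).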

Compound 4, half-maximal inhibitory concentration: 22800 nM
Compound 4: middle estimate off by 1.0-fold (0.00 log units), on the high side; low and high end bracket the measured number.
By their numbers in this assay, from the lowest: compound 2; then compounds 4, 3 and 1 (each within the scatter of the next).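

Changing the double bond from E to Z does not move the result in this assay beyond the scatter (a 1.0-fold lower number from compound 3 to compound 4 (0.01 log units; within the scatter)), and this pair isolates that single change: the fact that compounds 3 and 4 differ only in the configuration as drawn. Thiophen-2-yl in place of phenyl likewise stays within the scatter (a 1.1-fold lower number from compound 1 to compound 4 (0.02 log units; within the scatter)). Thiophen-2-yl in place of 4-(dimethylamino)phenyl gives a weaker result (a 2.3-fold higher number from compound 2 to compound 4 (0.35 log units; beyond the scatter)), so the dimethylamino compound alone stands apart here.

From the compounds shown here alone, whether double-bond geometry also makes no difference with 4-(dimethylamino)phenyl remains open. So does whether a carboxylic acid or a morpholine on that phenyl ring would match dimethylamino.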